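From 2-chlorobenzyl to butyl on a shared core

This account rests on a few compounds, and the source may have more. Where it says the series, first, only, none or still open, it means among the compounds named here.

In a functional assay on RAW264.7 cells (Mus musculus) for inhibition, read by Griess assay, with stated times of 2 h and 24 h (on this read-out higher numbers stand for weaker inhibition and lower numbers for stronger inhibition), compound 3 (`COc1ccc([C@@H]2CC(=O)c3c(O)cc(OCc4cn(Cc5ccccc5Cl)nn4)cc3O2)cc1O`) gives 6140 nM. Compound 2 (`COc1ccc([C@@H]2CC(=O)c3c(O)cc(OCc4cn(Cc5ccccc5)nn4)cc3O2)cc1O`) gives 11000 nM, and a 1.8-fold lower number from compound 2 to compound 3 (0.25 log units; within the scatter) shows these two cannot be told apart. Compound 1 (`COc1ccc([C@@H]2CC(=O)c3c(O)cc(OCc4cn(Cc5cccc(Cl)c5)nn4)cc3O2)cc1O`) gives 18200 nM, and a 3.0-fold lower number from compound 1 to compound 3 (0.47 log units; beyond the scatter) puts compound 3 clearly lower than compound 1.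

Compound 4 (`CCCCn1cc(COc2cc(O)c3c(c2)O[C@H](c2ccc(OC)c(O)c2)CC3=O)nn1`) carries a larger change: propyl in place of 2-chlorophenyl on a saturated chain carbon bound to an aromatic nitrogen. In other words, propyl replaces 2-chlorophenyl on a saturated chain carbon bound to an aromatic nitrogen, which also reads as 2-chlorobenzyl to butyl.

The measured steps are only a loose guide, as each one merely alters the chloro group and keeps the aromatic ring. Besides the two above, there is a 1.7-fold lower number from compound 1 to compound 2 (0.22 log units; within the scatter). Among the measured compounds shown here, no measurement shows what losing that ring does, so no large step can be argued for. The expected step is a 1.8-fold higher number from compound 3 to compound 4 (0.25 log units; within the scatter), which stays within the scatter. For compound 4 the estimate is 11000 nM, with an expected range of 4000 nM to 30000 nM.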

Compound 4, half-maximal inhibitory concentration: 13900 nM
Compound 4: middle estimate off by 1.3-fold (0.10 log units), on the low side, within the range that was stated.
By their numbers in this assay, from the lowest: compounds 3, 2, 4 and 1 (each within the scatter of the next, the first and the last beyond it).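

Replacing the ring with a flexible chain at this position changes little for two of the three benzyl-type compounds: there is a 1.3-fold higher number from compound 2 to compound 4 (0.10 log units; within the scatter) and a 1.3-fold lower number from compound 1 to compound 4 (0.12 log units; within the scatter) and both steps stay within the scatter, so in these pairs an aromatic ring is not required for a number of this size. Among the compounds shown here, compound 3 is the exception, with a 2.3-fold higher number from compound 3 to compound 4 (0.35 log units; beyond the scatter) and this modest step means that 2-chlorobenzyl is the only one of these groups that clearly separates from butyl. No measurement available here explains this difference.

On these data alone, it remains open whether a longer chain such as hexyl would give a similar number at this position. Also unresolved is how a butyl chain ending in an amine or a carboxylic acid would behave.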